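A few compounds are considered here, and "the series" means these few. Any claim that something is new, unique, unknown or untested is made for them only; others in the source may bear on it.

Measured compounds:
compound 1 `O=c1nc(NCc2cccc(F)c2)oc2c([N+](=O)[O-])cc(C(F)(F)F)cc12`: > 64 ug/mL
compound 2 `CC1COC2(CCN(c3cc(=O)c4cc(C(F)(F)F)cc([N+](=O)[O-])c4o3)CC2)O1`: 18.9 ug/mL

Both were tested in an ADME assay on Vero cells (Chlorocebus sabaeus) for cytotoxicity, read by MTT assay, with a stated time of 48 h; a lower number here means a stronger inhibitor, a higher number a weaker inhibitor. Compound 1 reached only the limit of the assay, > 64 ug/mL, so no number beyond that limit is known for it. Compound 2 gave a measured value of 18.9 ug/mL in this assay. Compound 1 thus stands at the edge of what the assay can report (the limit of > 64 ug/mL in this assay, at which 1 of the 2 values shown sits), while compound 2 lies inside the measurable range. Among the measured compounds shown here, no step between two measured compounds is available here, and compound 1 and compound 2 differ in more than one place, so their values only show where each stands on its own.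

The step under consideration leads from compound 1 to the untested compound 3 `O=c1nc(NCC2CCCCC2)oc2c([N+](=O)[O-])cc(C(F)(F)F)cc12`. The change is cyclohexyl in place of 3-fluorophenyl on a saturated chain carbon bound to a nitrogen on an aromatic ring. In this assay the step from compound 1 to compound 3 is expected to stay within the scatter of repeated measurements a step that the limit leaves unreadable from compound 1 to compound 3, because compound 1 already sits at the limit (the limit of > 64 ug/mL in this assay, at which 1 of the 2 values shown sits). Compound 3 is therefore estimated at 70 ug/mL, with a range from 40 ug/mL to 130 ug/mL, and a good chance that the assay again reports only a limit.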

Compound 3, half-maximal inhibitory concentration: 29.7 ug/mL
Beside the measured number, compound 3's estimate is 2.4-fold (0.37 log units) above it; measured number outside the range, below it.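

In this assay, compound 3 gives a true reading of 29.7 ug/mL, showing that a change at this position alone can bring a compound of this series into the measurable range. Replacing 3-fluorophenyl with cyclohexyl gives an at least 2.1-fold lower number from compound 1 to compound 3 (0.33 log units; beyond the scatter), and this size is only a minimum because the starting point is not an exact number: the limit of > 64 ug/mL in this assay, at which 1 of the 3 values shown sits. The change itself is simple: an aromatic carbon ring bearing a fluorine leaves, a non-aromatic carbon ring enters, and neither group carries a hydrogen-bond donor, a hydrogen-bond acceptor or a net charge.

This single step cannot separate the loss of the fluorine from the loss of the aromatic ring, since both change together; a plain benzyl group in the same place would tell those two apart. From the compounds shown here alone, whether the ring itself matters also remains open, and an open hexyl chain or a chain ending in an amine or a carboxylic acid at this position would test how much the reading depends on it.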